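From thiophen-2-yl to 4-methylphenyl on the thiazole

The source may hold more compounds than are shown below. What is called first, only, known or untested is meant among the compounds shown, and "the series" means these compounds.

Among the measured compounds shown here, compound 3 `Cc1nc(-c2cccs2)sc1COc1ccc2c(c1)OCC2CC(=O)O` stands highest of the three numbers measured so far: in a functional assay on CHO cells for agonist activity at Free fatty acid receptor 1 (Homo sapiens), read by FLIPR and calcium flux, tested at 100 nM (a higher number here means a stronger effect of the compound at the concentration tested, a lower number a weaker effect), compound 3 gives 35.2%. Compound 1 `Cc1nc(-c2ccccc2)oc1COc1ccc2c(c1)OCC2CC(=O)O` gives 7.15% in this assay, and compound 2 `O=C(O)CC1COc2cc(OCc3csc(-c4ccccc4)n3)ccc21` gives 0.15% in this assay; both lie beyond the scatter below compound 3. Compound 4 `Cc1ccc(-c2nc(C)c(COc3ccc4c(c3)OCC4CC(=O)O)s2)cc1` has not yet been measured. It differs from compound 3 in one place: 4-methylphenyl in place of thiophen-2-yl on an aromatic carbon. For the measured compounds named here, no step between measured compounds isolates this change, so its size is uncertain. A modest move, not clearly beyond the scatter in either direction, seems likely, and for compound 4 the expected step is a number 5.2 percentage points lower from compound 3 to compound 4 (within the scatter). Compound 4 is estimated to give 30% in this assay, within a range from 5% to 60%.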

Compound 4, a percentage reported as activity, at one concentration (the size of the read-out at that concentration, not a potency): 54.9%
Compound 4: middle estimate off by 24.9 percentage points, on the low side; measured number inside the range.
By their numbers in this assay, from the lowest: compounds 2 and 1 (each within the scatter of the next); then compound 3; then compound 4.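

Among the compounds shown here, on this aromatic carbon, next to the ring nitrogen and the ring sulfur, the single change to 4-methylphenyl in place of thiophen-2-yl moves this assay by a number 19.7 percentage points higher from compound 3 to compound 4 (beyond the scatter). For the compounds shown here, this is the only step that isolates one place, and it shows that the read-out depends on the aromatic ring carried here. Nothing measured accounts for the rise.

Going by these compounds, whether the six-membered ring or its methyl group carries the step stays open. So does how a methoxy group, a chlorine atom or an amine would read in place of that methyl group.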